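Compound 3: methoxy in place of chloro

This account rests on a few compounds, and the source may have more. Where it says the series, first, only, none or still open, it means among the compounds named here.

compound 1 `FC(F)(F)c1ccc2[nH]c(-c3cn(-c4ccccc4)nc3-c3ccc(Cl)cc3)nc2c1`: 41800 nM
compound 2 `O=C(OCc1ccccc1)c1ccc2[nH]c(-c3cn(-c4ccccc4)nc3-c3ccc(Cl)cc3)nc2c1`: > 50000 nM

Going by the values given here, in an ADME assay on HaCaT cells (Homo sapiens) for cytotoxicity, read by MTT assay, with a stated time of 48 h (on this read-out higher numbers stand for weaker inhibition and lower numbers for stronger inhibition), compound 1 gives 41800 nM, the only true number so far. Compound 2 reads > 50000 nM, which is a limit of the assay. The same ceiling applies across the set: the limit of > 50000 nM in this assay, at which 1 of the 2 values shown sits. Compound 3 `COc1ccc(-c2nn(-c3ccccc3)cc2-c2nc3cc(C(F)(F)F)ccc3[nH]2)cc1` carries methoxy in place of chloro on an aromatic carbon. Among the compounds with values here, the one measured step, an at least 1.1-fold higher number from compound 1 to compound 2 (0.07 log units; that floor lies within the scatter), replaces trifluoromethyl rather than chloro, so it gives no size for this change. The expected step is a 1.1-fold lower number from compound 1 to compound 3 (0.04 log units; within the scatter), with none expected beyond the scatter. For compound 3 the estimate is 38000 nM, with an expected range from 17000 nM to 60000 nM.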

Compound 3, half-maximal inhibitory concentration: > 50000 nM
Compound 3 gave a limit, no number; the forecaster's own chance of this, stated with the estimate: 30%; at least 1.3-fold (0.11 log units) between middle value and limit.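

Methoxy in place of chloro gives the first reading for a change at this place on the ring, and in this assay it shows an at least 1.1-fold higher number from compound 1 to compound 3 (0.07 log units; that floor lies within the scatter). Compound 3 reads at a limit and not a number, so this floor gives no true size for the change. The ceiling now holds most of the set: the limit of > 50000 nM in this assay, at which 2 of the 3 values shown sit.

From the compounds shown here alone, whether any group at this place moves the reading beyond the scatter stays open. An amine or a carboxylic acid in place of chloro would bear on that question.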